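Swapping an aryl ether for a tert-butylphenyl group

A few compounds are considered here, and "the series" means these few. Any claim that something is new, unique, unknown or untested is made for them only; others in the source may bear on it.

Compound 1, `COc1cccc(CNCCCNc2ccnc3cc(CCC(C)C)ccc23)c1O`, 9.47
Compound 2, `COc1cccc(Oc2ccc3c(NCCCNCc4cccc(OC)c4O)ccnc3c2)c1`, 9.28
Compound 3, `COc1cccc(CNCCCNc2ccnc3cc(Oc4cccc(N(C)C)c4)ccc23)c1O`, 9.28

In a physicochemical assay for acid dissociation, compound 3 stands level with compound 2 at the digits shown, and the two together give the lowest of the three numbers, while compound 1 sits a little higher: a number 0.19 log units lower from compound 1 to compound 3 (within the scatter). Compound 4, `COc1cccc(CNCCCNc2ccnc3cc(-c4ccc(C(C)(C)C)cc4)ccc23)c1O`, has not been measured. It differs from compound 3 in one place: 4-(tert-butyl)phenyl in place of 3-(dimethylamino)phenoxy on an aromatic carbon.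

Within the data shown here, the measured steps at this same position, a number 0.19 log units lower from compound 1 to compound 2 (within the scatter), a number 0.19 log units lower from compound 1 to compound 3 (within the scatter) and no change at the digits printed from compound 2 to compound 3 (within the scatter), all stay within the scatter, so changes at this carbon have not moved the number so far. A step of a number 0.07 log units higher from compound 3 to compound 4 (within the scatter) is therefore expected, no larger than the scatter. Compound 4 is estimated at 9.35, in a range from 9 to 9.7.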

Compound 4, acid dissociation constant: 9.47
The estimate for compound 4 lay 0.12 log units below the measured number; measured number inside the range.
By their numbers in this assay, from the lowest: compounds 2, 3, 1 and 4 (each within the scatter of the next).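

In this assay, 4-(tert-butyl)phenyl, which is all carbon and has no hydrogen-bond acceptors, gives a number 0.19 log units higher from compound 3 to compound 4 (within the scatter), a number 0.19 log units higher from compound 2 to compound 4 (within the scatter) and no change at the digits printed from compound 1 to compound 4 (within the scatter). A substituent with no oxygen or nitrogen at this aromatic carbon therefore stays within the scatter of the phenoxy groups and isopentyl, so neither the ether oxygen nor the ring's extra heteroatom is needed to keep the number where it is. Nothing here offers an explanation for this insensitivity. Still open, from the compounds shown here alone, is whether a carboxylic acid or a nitrile on this carbon would also stay within the scatter.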